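The source may hold more compounds than are shown below. What is called first, only, known or untested is meant among the compounds shown, and "the series" means these compounds.

For the measured compounds named here, compound 1 `CCc1nc(Cl)c(C2C(C(=O)OC)=C(C)NC(C)=C2C(=O)OC(C)C)[nH]1` is the stronger of the two compounds measured so far in an assay on ileum for inhibition of Voltage-dependent L-type calcium channel subunit alpha-1C (Cavia porcellus); on this read-out lower numbers stand for stronger inhibition and higher numbers for weaker inhibition: compound 1 gives 0.488 nM, the lowest of the two numbers. Its nearest neighbour, compound 2 `CCc1nc(Cl)c(C2C(C(=O)OC)=C(C)NC(C)=C2C(=O)OC(C)(C)C)[nH]1`, gives 50.8 nM in this assay. Going by the values given here, the one step measured so far, a 100-fold higher number from compound 1 to compound 2 (2.02 log units; beyond the scatter), came from a methyl in place of hydrogen on a saturated chain carbon bound to an oxygen next to a carbonyl group and two saturated chain carbons.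

Compound 3 `CCOC(=O)C1=C(C)NC(C)=C(C(=O)OC(C)C)C1c1[nH]c(CC)nc1Cl` has not yet been measured in this assay. It differs from compound 1 by methyl in place of hydrogen on a saturated chain carbon bound to an oxygen next to a carbonyl group, which, read one bond further out, turns methoxycarbonyl into ethoxycarbonyl. Among the compounds with values here, the only measured step, a 100-fold higher number from compound 1 to compound 2 (2.02 log units; beyond the scatter), also adds a methyl to a saturated chain carbon on an ester oxygen, but at the other ester and on a carbon that already carries two saturated chain carbons; it is a weak guide here. With no closer comparison, the expectation for compound 3 is a step of a 1.4-fold higher number from compound 1 to compound 3 (0.16 log units; within the scatter), within the scatter, giving an estimated 0.7 nM in this assay, with a range from 0.2 nM to 2.5 nM.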

Compound 3, half-maximal inhibitory concentration: 0.564 nM
The estimate for compound 3 lay 1.2-fold (0.09 log units) above the measured number; low and high end bracket the measured number.
By their numbers in this assay, from the lowest: compounds 1 and 3 (each within the scatter of the next); then compound 2.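

Replacing methoxycarbonyl with ethoxycarbonyl gives a 1.2-fold higher number from compound 1 to compound 3 (0.06 log units; within the scatter) in this assay, so this added methyl on a saturated chain carbon bound to an oxygen next to a carbonyl group leaves no change that this assay can distinguish from scatter. For the compounds shown here, until now, the only measured step that added a methyl to a carbon on an ester oxygen was a 100-fold higher number from compound 1 to compound 2 (2.02 log units; beyond the scatter), and this result shows that such an addition does not bring a large rise in the number everywhere. Nothing available here explains why these two steps differ so much in size.

On these data alone, whether this position would accept still larger groups stays open, for example a longer chain as in propoxycarbonyl or butoxycarbonyl, or a branched one as in tert-butoxycarbonyl. The compounds shown also say nothing about how a carboxylic acid or an amide in place of this ester would read in this assay, so one small step marks only the beginning of what can be learned about this position.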